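Cytotoxicity notes on a cyclic sulfonylurea series

The source may hold more compounds than are shown below. What is called first, only, known or untested is meant among the compounds shown, and "the series" means these compounds.

Measured so far:
Compound 1 `O=C1N(Cc2ccccc2)c2cccn2S(=O)(=O)N1Cc1cccc(F)c1` — in an ADME assay on MT4 cells (Homo sapiens) for cytotoxicity, read by MTT assay, with a stated time of 5 days (a higher number here means that more compound is tolerated, a lower number that less compound is tolerated), compound 1 gives > 288000 nM, which is a limit of the assay.
Compound 2 `C=CCN1C(=O)N(Cc2ccccc2)S(=O)(=O)n2cccc21` — in this assay compound 2 gives > 802000 nM, also a limit of the assay.

Compound 2 therefore stands only at a limit, and compound 1 likewise sits at a limit; no number separates them. Compound 3 `O=C1N(Cc2ccccc2)c2cccn2S(=O)(=O)N1Cc1ccccc1` differs from compound 2 by phenyl in place of vinyl on a saturated chain carbon bound to an amide-type nitrogen in a ring. Among the measured compounds shown here, no step between measured compounds exists, so no direction is known; no change beyond the scatter is expected, and a limit is again likely. Compound 3 is estimated at 300000 nM with a range of 100000 nM to 1000000 nM. The expected step is an at least 2.6-fold lower number from compound 2 to compound 3 (0.42 log units; beyond the scatter).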

Compound 3, half-maximal cytotoxic concentration: 196000 nM
Beside the measured number, compound 3's estimate is 1.5-fold (0.18 log units) above it, within the range that was stated.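

In this assay, among the compounds shown here, compound 3 is the first compound here to give a number rather than a limit. Phenyl in place of vinyl on a saturated chain carbon bound to an amide-type nitrogen in a ring gives an at least 4.0-fold lower number from compound 2 to compound 3 (0.61 log units; beyond the scatter), so allyl to benzyl at this place lowers the number beyond the scatter. Hydrogen in place of fluoro on an aromatic carbon gives an at least 1.4-fold lower number from compound 1 to compound 3 (0.16 log units; that floor lies within the scatter), and this floor fixes no direction for that change.

From the compounds shown here alone, the true size of both steps stays open, since compound 1 and compound 2 stand only at limits. Also open, going by these compounds, is how an amine, a carboxylic acid or a longer chain at this place would read.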